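The compounds below may be only part of what the source reports. "The series", "measured", "known", "first", "only" and "open" are said of these compounds alone.

Working notes on the series, read in a functional assay on MGC-803 cells (Homo sapiens) for inhibition, read by MTT assay, with a stated time of 72 h; on this read-out lower numbers stand for stronger inhibition and higher numbers for weaker inhibition. Compound 1 (`CC(C)c1ccc(NC(=O)C2CCN(C/C=C/c3ccccc3)CC2)cc1`) gives 5200 nM, compound 2 (`COc1ccc(NC(=O)C2CCN(C/C=C/c3ccccc3)CC2)cc1`) gives 58200 nM, and compound 3 (`COc1cccc(NC(=O)C2CCN(C/C=C/c3ccccc3)CC2)c1`) gives 37200 nM. Compound 3 belongs to the higher pair of numbers. The two methoxy compounds sit together, with a 1.6-fold lower number from compound 2 to compound 3 (0.19 log units; within the scatter). The isopropyl compound lies apart, with an 11-fold higher number from compound 1 to compound 2 (1.05 log units; beyond the scatter) and a 7.2-fold higher number from compound 1 to compound 3 (0.85 log units; beyond the scatter).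

The next compound is compound 4 (`O=C(Nc1ccc(F)c(Br)c1)C1CCN(C/C=C/c2ccccc2)CC1`), and the change is 3-bromo-4-fluorophenyl in place of 3-methoxyphenyl on an amide-type nitrogen. This puts 3-bromo-4-fluorophenyl in place of 3-methoxyphenyl on an amide-type nitrogen. Going by the values given here, no measured compound carries a halogen, so the steps above are only a loose guide. Among the compounds with values here, they show that the one compound without methoxy has the lowest number, and that shifting the methoxy gives no resolved change. A modest step to a lower number is therefore expected, falling short of the full gap to compound 1. The expected step is a 3.1-fold lower number from compound 3 to compound 4 (0.49 log units; beyond the scatter). For compound 4 the estimated value is 12000 nM, with an expected range of 3000 nM to 45000 nM.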

Compound 4, half-maximal inhibitory concentration: 9270 nM
Compound 4: middle estimate off by 1.3-fold (0.11 log units), on the high side, and the stated range covers the measured number.
By their numbers in this assay, from the lowest: compounds 1 and 4 (each within the scatter of the next); then compounds 3 and 2 (each within the scatter of the next).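

In this assay, the 3-bromo-4-fluorophenyl group on the amide-type nitrogen separates compound 4 from both methoxy compounds, with a 4.0-fold lower number from compound 3 to compound 4 (0.60 log units; beyond the scatter) and a 6.3-fold lower number from compound 2 to compound 4 (0.80 log units; beyond the scatter), so the isopropyl compound is no longer alone at the low end. The comparison with the isopropyl compound gives a 1.8-fold higher number from compound 1 to compound 4 (0.25 log units; within the scatter), which leaves the 3-bromo-4-fluorophenyl and 4-isopropylphenyl groups unresolved at this position even though they share no substituent. Nothing on hand accounts for the difference from the methoxy compounds.

Compound 4 carries bromine and fluorine together, so the shown compounds do not divide the step between the two halogens, and a phenyl group carrying only bromine or only fluorine would address that. Also open, as far as these compounds go, is how an amine or a carboxylic acid on this phenyl ring would read.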